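A few compounds are considered here, and "the series" means these few. Any claim that something is new, unique, unknown or untested is made for them only; others in the source may bear on it.

The measured compounds:
Compound 1, `CC(=O)OC[C@H]1O[C@@H](n2cc(-c3cn(Cc4ccc(C(C)(C)C)cc4)nn3)c(=O)[nH]c2=O)C[C@@H]1OC(C)=O`, gives 90.4%.
Compound 2, `O=c1[nH]c(=O)n([C@H]2C[C@H](O)[C@@H](CO)O2)cc1-c1cn(Cc2ccccc2)nn1`, gives 92.1%.
Compound 3, `CCCc1cc(-c2cn([C@H]3C[C@H](OC(C)=O)[C@@H](COC(C)=O)O3)c(=O)[nH]c2=O)on1`, gives 88.1%.

All three numbers come from a functional assay on PC-3 cells (Homo sapiens) for cytotoxicity, read by sulforhodamine B assay, tested at 10 uM; on this read-out lower numbers stand for less inhibition and higher numbers for more inhibition at the one concentration tested (going by the name of the read-out). Compound 3 stands at the low end of the three, but its gap to compound 1 and its gap to compound 2 both lie within the usual scatter of repeated measurements, so the three compounds cannot be told apart on this read-out.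

Compound 4, `CC(=O)OC[C@H]1O[C@@H](n2cc(-c3cc(-c4ccc(C(C)(C)C)cc4)no3)c(=O)[nH]c2=O)C[C@@H]1OC(C)=O`, has not yet been measured. It differs from compound 3 in one place: 4-(tert-butyl)phenyl in place of propyl on an aromatic carbon. The group that enters brings a six-membered aromatic ring of carbon only, while the acetylated sugar and the shared core stay unchanged. Among the compounds with values here, no measured pair here shows what such a swap does, so the expectation rests only on how close all three measured values are to one another. The step expected from the change, a number 0.1 percentage points lower from compound 3 to compound 4 (within the scatter), is small and is not expected to reach beyond the scatter. Compound 4 is therefore estimated at 88%, with a range from 74% to 95%.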

Compound 4, a percentage reported as inhibition, at one concentration (the size of the read-out at that concentration, not a potency): 27.5%
Beside the measured number, compound 4's estimate is 60.5 percentage points above it, and the stated range ends above it.
By their numbers in this assay, from the lowest: compound 4; then compounds 3, 1 and 2 (each within the scatter of the next).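

At this aromatic carbon of the five-membered aromatic ring with 1 nitrogen and 1 oxygen, the choice of group matters: in this assay, 4-(tert-butyl)phenyl in place of propyl gives a number 60.6 percentage points lower from compound 3 to compound 4 (beyond the scatter) with the acetylated sugar and the shared core unchanged. The earlier compounds shown here could not be told apart and formed no pair differing in one place, so they gave no sign that a single swap could matter this much. Nothing available here explains why this change goes with so much less inhibition at the one concentration tested.

A plain phenyl or a longer chain such as hexyl at this place would help show whether the loss follows the ring, the tert-butyl on it, or the chain length. Going by these compounds, how an amine or a carboxylic acid on that ring would read remains open, as does whether the same swap would act alike on a sugar with free hydroxyl groups.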